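Compound 3 to compound 4: 4-fluorobenzyl to 4-methylbenzyl

This account rests on a few compounds, and the source may have more. Where it says the series, first, only, none or still open, it means among the compounds named here.

Compound 1 `COc1ccc(S(=O)(=O)Oc2ccccc2/C=C(\C#N)C(=O)Nc2nnc(-c3cccs3)s2)cc1`: > 20000 nM, a limit
Compound 2 `COc1ccc(S(=O)(=O)Oc2ccccc2/C=C(\C#N)C(=O)Nc2nnc(Cc3ccccc3)s2)cc1`: > 50000 nM, a limit
Compound 3 `COc1ccc(S(=O)(=O)Oc2ccccc2/C=C(\C#N)C(=O)Nc2nnc(Cc3ccc(F)cc3)s2)cc1`: > 50000 nM, a limit

In an ADME assay on HEK-293T cells (Homo sapiens) for inhibition, read by CCK-8 assay, with a stated time of 48 h (a higher number here means a weaker inhibitor, a lower number a stronger inhibitor), compound 3 stands at > 50000 nM, which is a limit and not a number. Compound 4 `COc1ccc(S(=O)(=O)Oc2ccccc2/C=C(\C#N)C(=O)Nc2nnc(Cc3ccc(C)cc3)s2)cc1` carries methyl in place of fluoro on an aromatic carbon, para to a large group: methyl in place of fluoro on an aromatic carbon. The closest measured change is a step that the two limits leave unreadable from compound 2 to compound 3. The other two changes, a step that the two limits leave unreadable from compound 1 to compound 2 and a step that the two limits leave unreadable from compound 1 to compound 3, give no size either. No size or direction can therefore be carried over from a measured step. The expectation rests on (the limit of > 50000 nM in this assay, at which 2 of the 3 values shown sit). The expected step is a number no higher from compound 3 to compound 4 (the limit leaves the size open), with nothing expected beyond the scatter in this assay. For compound 4 the estimate is 50000 nM, with an expected range of 25000 nM to 100000 nM.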

Compound 4, half-maximal inhibitory concentration: > 50000 nM
Compound 4: a limit, no number; the forecaster's own chance of this, stated with the estimate: 90%; the middle value sits exactly at the limit.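

Among these compounds, all four values, including compound 4 at > 50000 nM, are limits, and no step from compound 1, compound 2 or compound 3 to compound 4 can be read. The compounds shown leave open whether the thiophen-2-yl, benzyl, 4-fluorobenzyl and 4-methylbenzyl groups differ at all in this assay.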